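The source may report more compounds than this note shows. Statements on the series, on what has been measured and on what is new or still open speak of the compounds shown alone.

As far as these compounds go, the series rests on two measured compounds and one that is still open. Compound 1 `Cc1cc(C(=O)/C=C/c2ccc(N3CCCCC3)cc2)c(C)s1` is an open-chain enone; in an ADME assay on CCRF-CEM cells (Homo sapiens) for cytotoxicity, with a stated time of 5 days (a lower number here means a stronger inhibitor, a higher number a weaker inhibitor), compound 1 gives 16600 nM. Compound 2 `Cc1ccsc1C1=NNC(c2ccc(N3CCCCC3)cc2)C1` carries the same aryl piperidine but closes the linker into a five-membered ring; in this assay compound 2 gives 2300 nM, the lower of the two numbers, and its gap to compound 1 lies beyond the usual scatter. Compound 3 `Clc1cc(C2=NNC(c3ccc(N4CCCCC4)cc3)C2)c(Cl)s1` keeps the core of compound 2 and changes only the thiophene: 2,5-dichlorothiophen-3-yl in place of 3-methylthiophen-2-yl on a carbon with a double bond to nitrogen. For the measured compounds named here, no measured pair shows this change, so its effect is not known from the data. The author expects compound 3 to stay near compound 2, with a step of a 1.3-fold lower number from compound 2 to compound 3 (0.11 log units; within the scatter) that is likely to remain within or close to the scatter, in no firmly predicted direction. For compound 3 in this assay the estimate is 1800 nM, with a range from 350 nM to 9000 nM.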

Compound 3, half-maximal inhibitory concentration: 37700 nM
Beside the measured number, compound 3's estimate is 21-fold (1.32 log units) below it, and the stated range ends below it.
By their numbers in this assay, from the lowest: compound 2; then compound 1; then compound 3.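

On the carbon with a double bond to nitrogen, the thiophene is not interchangeable in this assay: 2,5-dichlorothiophen-3-yl in place of 3-methylthiophen-2-yl brings a 16-fold higher number from compound 2 to compound 3 (1.21 log units; beyond the scatter), so compound 3 is the weaker inhibitor of this pair. The two groups share one five-membered aromatic ring with 1 hetero atom, the same hydrogen-bond counts and no net charge, so the step arises without any change in those features, although the swap alters both the ring substituents and the point of attachment. No supporting measurement bears on why the number rises.

As far as these compounds go, whether the chlorines or the point of attachment carry the step stays open. A 3-chlorothiophen-2-yl or an unsubstituted thiophen-2-yl on this carbon could fall near compound 2 or near compound 3.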